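A few compounds are considered here, and "the series" means these few. Any claim that something is new, unique, unknown or untested is made for them only; others in the source may bear on it.

Values in a toxicity assay on MT4 cells (Homo sapiens) for cytotoxicity, read by MTT assay, with a stated time of 5 days; on this read-out lower numbers stand for higher toxicity in this test and higher numbers for lower toxicity in this test:
Compound 1 `Cc1cc(-c2ccco2)cc(C)c1Nc1ccnc(Nc2ccc(C#N)cc2)n1`: 1700 nM
Compound 2 `Cc1cc(-c2cncnc2)cc(C)c1Nc1ccnc(Nc2ccc(C#N)cc2)n1`: 6800 nM
Compound 3 `Cc1cc(-c2ccnc3ccccc23)cc(C)c1Nc1ccnc(Nc2ccc(C#N)cc2)n1`: 3500 nM

Compound 3 stands in the middle of the three numbers, as shown by a 1.9-fold lower number from compound 2 to compound 3 (0.29 log units; within the scatter) and a 2.1-fold higher number from compound 1 to compound 3 (0.31 log units; beyond the scatter). Compound 4 `Cc1csc(-c2cc(C)c(Nc3ccnc(Nc4ccc(C#N)cc4)n3)c(C)c2)c1` carries one change: 4-methylthiophen-2-yl in place of quinolin-4-yl on an aromatic carbon. Among the compounds with values here, the swaps at this place so far gave a 4.0-fold higher number from compound 1 to compound 2 (0.60 log units; beyond the scatter) and a 2.1-fold higher number from compound 1 to compound 3 (0.31 log units; beyond the scatter), both modest. The entering five-membered aromatic ring resembles the furan-2-yl of compound 1, which gives 1700 nM, so the number may lean lower in this assay, though probably not beyond the scatter. The expected change is a 1.5-fold lower number from compound 3 to compound 4 (0.16 log units; within the scatter). For compound 4 the estimated value is 2400 nM, with an expected range of 900 nM to 6500 nM.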

Compound 4, half-maximal cytotoxic concentration: 34000 nM
The estimate for compound 4 lay 14-fold (1.15 log units) below the measured number, and the stated range ends below it.
By their numbers in this assay, from the lowest: compound 1; then compounds 3 and 2 (each within the scatter of the next); then compound 4.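

In this assay, a five-membered aromatic ring at this position does not fix the number: 4-methylthiophen-2-yl in place of furan-2-yl gives a 20-fold higher number from compound 1 to compound 4 (1.30 log units; beyond the scatter). The same group also stands clear of the six-membered aromatic groups, with a 5.0-fold higher number from compound 2 to compound 4 (0.70 log units; beyond the scatter) and a 9.7-fold higher number from compound 3 to compound 4 (0.99 log units; beyond the scatter), so compound 4 shows the lowest toxicity in this test among the four. No measurement at hand accounts for these steps.

Open, on these data alone, is whether the methyl or the sulfur-containing ring carries the steps. Also open, as far as these compounds go, is how an amine or a carboxylic acid on this ring would read in this assay.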